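The source may hold more compounds than are shown below. What is called first, only, known or untested is meant among the compounds shown, and "the series" means these compounds.

Compound 1 `CSc1nnc(COc2cc(C)c3c(C)cc(=O)oc3c2)o1` in a functional assay on MCF7 cells (Homo sapiens) for antiproliferative activity, read by MTT assay, with a stated time of 24 h (a lower number here means a stronger inhibitor, a higher number a weaker inhibitor), gives > 100000 nM, which is a limit of the assay. Compound 2 `CCSc1nnc(COc2cc(C)c3c(C)cc(=O)oc3c2)o1` in this assay gives > 100000 nM, again a limit of the assay. Compound 3 `Cc1cc(OCc2nnc(SCc3ccccc3)o2)cc2oc(=O)cc(C)c12` in this assay gives > 100000 nM, also a limit of the assay.

The three compounds share one core and differ only in the group on the saturated chain carbon bound to a sulfur. The steps among them, a step that the two limits leave unreadable from compound 1 to compound 2, a step that the two limits leave unreadable from compound 1 to compound 3 and a step that the two limits leave unreadable from compound 2 to compound 3, cannot be sized because every value sits at the limit of > 100000 nM in this assay, at which 3 of the 3 values shown sit. Among the compounds with values here, compound 3 therefore stands nowhere distinguishable from the others: its value is a limit, and the series so far contains no number at all.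

Compound 4 `Cc1cc(OCc2nnc(SCc3cccc(F)c3)o2)cc2oc(=O)cc(C)c12` differs from compound 3 in one place: fluoro in place of hydrogen on an aromatic carbon. Within the data shown here, the measured steps all touch the group on that same sulfur-bound carbon, but none of them is readable, so they give no precedent for the size or direction of this change. In this assay the step from compound 3 to compound 4 is expected to be a number no higher from compound 3 to compound 4 (the limit leaves the size open), that is, nothing beyond the scatter and most likely another limit. Compound 4 is accordingly estimated at 100000 nM, within 30000 nM to 300000 nM.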

Compound 4, half-maximal inhibitory concentration: 26000 nM
Beside the measured number, compound 4's estimate is 3.8-fold (0.59 log units) above it, outside the stated range (below it).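

In this assay, within the data shown here, fluoro on an aromatic carbon, meta to a large group, is the first change that can be read, as an at least 3.8-fold lower number from compound 3 to compound 4 (0.58 log units; beyond the scatter). Putting 3-fluorophenyl in place of the methyl or the hydrogen on the saturated chain carbon bound to the sulfur likewise gives an at least 3.8-fold lower number from compound 2 to compound 4 (0.58 log units; beyond the scatter) and an at least 3.8-fold lower number from compound 1 to compound 4 (0.58 log units; beyond the scatter), whereas the steps among the first three compounds cannot be read, so the series now has a measurable difference at this end of the molecule. All three new steps give only a minimum size because the compounds they start from sit at a limit: the limit of > 100000 nM in this assay, at which 3 of the 4 values shown sit.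

As far as these compounds go, it remains open whether this drop belongs to fluoro in particular, as chloro, methoxy or a nitrile on the same aromatic carbon would show, and whether fluoro on another carbon of the ring would do the same. Also open, from the compounds shown here alone, is whether the same 3-fluorophenyl group would keep compound 4's 26000 nM if a longer chain joined it to the sulfur.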